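One Added Methyl at Two Different Places

The compounds below may be only part of what the source reports. "The series", "measured", "known", "first", "only" and "open" are said of these compounds alone.

Compound 1 `CC(C)NC(=O)Nc1nc2ccc([N+](=O)[O-])cc2s1` carries a urea with an isopropyl group; compound 2 `CC(C)(C)NC(=O)Nc1nc2ccc([N+](=O)[O-])cc2s1` is its tert-butyl counterpart. In a functional assay (thoracic aorta, Rattus norvegicus, strain Wistar) (on this read-out lower numbers stand for an effect already at smaller amounts and higher numbers for an effect only at larger amounts of compound), compound 1 gives 15700 nM, and compound 2 gives 10800 nM. The change between them is methyl in place of hydrogen on a saturated chain carbon bound to an amide-type nitrogen and two saturated chain carbons, and it produced a 1.5-fold lower number from compound 1 to compound 2 (0.16 log units; within the scatter).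

Compound 3 `Cc1ccc2nc(NC(=S)NCc3ccccc3)sc2c1` belongs to a different series, and the difference between the core of compound 1 and the core of compound 3 is not broken down here. In this assay compound 3 reaches only a limit of the assay, > 100000 nM. Compound 3 thus stands at the limit of > 100000 nM in this assay, at which 1 of the 3 values shown sits.

Compound 4 `CCc1ccc2nc(NC(=S)NCc3ccccc3)sc2c1` has not yet been measured. It differs from compound 3 by methyl in place of hydrogen on a saturated chain carbon bound to an aromatic carbon. This is the same kind of change as that from compound 1 to compound 2, but the surroundings differ: in the first pair the methyl enters on a saturated chain carbon bound to an amide-type nitrogen and two saturated chain carbons, here on a saturated chain carbon bound to an aromatic carbon.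

Because a 1.5-fold lower number from compound 1 to compound 2 (0.16 log units; within the scatter) stays within the scatter, the change to compound 4 is expected to bring a step of about a number no higher from compound 3 to compound 4 (the limit leaves the size open), which is small. Compound 4 is therefore estimated at roughly 100000 nM, most likely between 30000 nM and 300000 nM, with a good chance that it again reaches only a limit.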

Compound 4, half-maximal effective concentration: > 100000 nM
Compound 4 ended at the assay's limit (the forecaster's own chance of this, stated with the estimate: 70%); the middle value lies on the limit itself.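

Compound 3 and compound 4 both end at a limit of this assay rather than at a number, and the step between them cannot be read: the limit of > 100000 nM in this assay, at which 2 of the 4 values shown sit.

The compounds shown leave open whether going from methyl to ethyl changes anything at all on the core of compound 3, and whether an added methyl acts there as it does between compound 1 and compound 2.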